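Longer Amine Chain on the Isopropylthio Core

A few compounds are considered here, and "the series" means these few. Any claim that something is new, unique, unknown or untested is made for them only; others in the source may bear on it.

Three measured compounds share one core. Compound 1 `CCCCCCCNc1nc(SCC)nc2ncccc12` gives 2600 nM in a functional assay on MDA-MB-231 cells (Homo sapiens) for cytotoxicity, read by neutral red uptake, with a stated time of 72 h; a higher number here means a weaker inhibitor, a lower number a stronger inhibitor. Compound 2 `CCCCNc1nc(SC(C)C)nc2ncccc12` gives 15700 nM in this assay, and compound 3 `CCCCCNc1nc(SC(C)C)nc2ncccc12` gives 5600 nM in this assay. Compound 3 therefore stands second highest of the three numbers, with compound 1 nearest below it and compound 2 furthest above it. Compound 4 `CCCCCCCNc1nc(SC(C)C)nc2ncccc12` has not been measured; it differs from compound 3 by ethyl in place of hydrogen on a saturated chain carbon, five bonds along the chain from a nitrogen on an aromatic ring. Among the compounds with values here, one measured step bears directly on this change, the same kind of lengthening cut one bond nearer the ring: a 2.8-fold lower number from compound 2 to compound 3 (0.45 log units; beyond the scatter). Compound 1, which shares the longer chain of compound 4 but differs elsewhere, also gives a lower number than compound 3. A further fall beyond the scatter is therefore expected: a 2.5-fold lower number from compound 3 to compound 4 (0.41 log units; beyond the scatter). Compound 4 is estimated at 2200 nM in this assay, with a range from 900 nM to 5500 nM.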

Compound 4, half-maximal inhibitory concentration: 7000 nM
Compound 4: the middle estimate sits 3.2-fold (0.50 log units) below what was measured; the measured number lies above the stated range.
By their numbers in this assay, from the lowest: compound 1; then compounds 3 and 4 (each within the scatter of the next); then compound 2.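

The fall seen with the first lengthening does not carry on at this position: in this assay, ethyl in place of hydrogen, five bonds along the chain from a nitrogen on an aromatic ring, gives a 1.3-fold higher number from compound 3 to compound 4 (0.10 log units; within the scatter). The longer chain still stands apart from the shorter one, with a 2.2-fold lower number from compound 2 to compound 4 (0.35 log units; beyond the scatter). Methyl in place of hydrogen on the carbon bound to a sulfur gives a 2.7-fold higher number from compound 1 to compound 4 (0.43 log units; beyond the scatter), and the same kind of change reads differently in the two settings: the same change on two cores in this assay, a 2.8-fold lower number (0.45 log units; beyond the scatter) from compound 2 to compound 3 and a 2.7-fold higher number (0.43 log units; beyond the scatter) from compound 1 to compound 4, 7.5-fold (0.88 log units) apart, beyond the scatter of two such steps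

As far as these compounds go, whether a hexyl chain, an octyl chain or a phenyl ring at the end of the amine chain would move the number remains open. So does how a pentyl chain behaves with ethyl rather than isopropyl on the sulfur.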